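This account rests on a few compounds, and the source may have more. Where it says the series, first, only, none or still open, it means among the compounds named here.

Compound 1 (`O=C(CCl)NC(=O)Nc1ccc2c(c1)CCC2`): 1700 nM
Compound 2 (`O=C(CCl)NC(=O)Nc1ccc(C2CCCCC2)cc1`): 900 nM

In a functional assay on M21 cells (Homo sapiens) for inhibition, read by sulforhodamine B assay, with a stated time of 48 h (a lower number here means a stronger inhibitor of growth, a higher number a weaker inhibitor of growth), compound 2 gives 900 nM and so lies within the scatter of compound 1 (1700 nM). Compound 3 (`CC(C)(C)c1ccc(NC(=O)NC(=O)CCl)cc1`) carries tert-butyl in place of cyclohexyl on an aromatic carbon, para to a group of 8 heavy atoms (tert-butyl in place of cyclohexyl on an aromatic carbon). For the measured compounds named here, no measured pair shows this change, so the data offer no direct guide to it. In this assay a step no larger than the scatter is expected, with no firm direction. The estimated shift is small (a 1.3-fold higher number from compound 2 to compound 3 (0.12 log units; within the scatter)) and stays within the scatter. The estimate for compound 3 is 1200 nM (expected range 500 nM to 3000 nM).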

Compound 3, concentration for 50% growth inhibition: 1100 nM
Compound 3: the middle estimate sits 1.1-fold (0.04 log units) above what was measured, within the range that was stated.
By their numbers in this assay, from the lowest: compounds 2, 3 and 1 (each within the scatter of the next).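

In this assay, tert-butyl in place of cyclohexyl on an aromatic carbon, para to a group of 8 heavy atoms, gives a 1.2-fold higher number from compound 2 to compound 3 (0.09 log units; within the scatter). At this position, then, the six-membered non-aromatic ring can give way to a group with no ring and fewer heavy atoms, and the two numbers stay within the scatter. The compounds shown leave open how an amine or a carboxylic acid would read at this position, since both groups compared here hold carbon only. No measurement at hand bears on the reason for this result.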